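From 4-methylphenyl to 3-cyanophenyl on the shared core

The source may report more compounds than this note shows. Statements on the series, on what has been measured and on what is new or still open speak of the compounds shown alone.

Compound 1 `Cc1ccc(-c2cnc(NC(=O)c3ccc(F)cc3)n2C)cc1` gives 60000 nM
Compound 2 `COc1ccc(-c2cnc(NC(=O)c3ccc(F)cc3)n2-c2ccccc2)cc1` gives 8800 nM
Compound 3 `Cn1c(-c2ccc([N+](=O)[O-])cc2)cnc1NC(=O)c1ccc(F)cc1` gives > 50000 nM

In a toxicity assay on THP-1 cells (Homo sapiens) for inhibition (on this read-out higher numbers stand for lower toxicity in this test and lower numbers for higher toxicity in this test), compound 1 (60000 nM) holds the higher of the two numbers, and compound 2 (8800 nM) lies lower, beyond the scatter. The entry for compound 3 (> 50000 nM) is a limit and not a number.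

Compound 4 `Cn1c(-c2cccc(C#N)c2)cnc1NC(=O)c1ccc(F)cc1` has not yet been measured. It carries 3-cyanophenyl in place of 4-methylphenyl on an aromatic carbon of the core of compound 1 (3-cyanophenyl in place of 4-methylphenyl on an aromatic carbon). Among the measured compounds shown here, the only measured step at this place puts nitro in place of methyl on the aromatic ring, and it is a step that the limit leaves unreadable from compound 1 to compound 3 with no size to carry over. The data therefore give no ground for expecting a step beyond the scatter in this assay and only a slight lowering is expected. The expected change is a 1.5-fold lower number from compound 1 to compound 4 (0.18 log units; within the scatter) and it is an estimate only. The estimated value for compound 4 is 40000 nM with an expected range of 15000 nM to 80000 nM and the assay may report only a limit.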

Compound 4, half-maximal cytotoxic concentration: > 100000 nM
Compound 4: no number, only a limit (the forecaster's own chance of this, stated with the estimate: 40%); middle value at least 2.5-fold (0.39 log units) from the limit.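

In this assay, among the compounds shown here, 3-cyanophenyl in place of 4-methylphenyl gives the first step at this position whose direction can be read: an at least 1.6-fold higher number from compound 1 to compound 4 (0.22 log units; that floor lies within the scatter). The floor of that step does not establish a change beyond the scatter, but it does show that this exchange on the aromatic carbon of the shared core brings no lowering of the number. The entry for compound 4 is a limit and not a number: the limit of > 100000 nM in this assay, at which 1 of the 4 values shown sits.

On these data alone, the limit gives only a floor, so the true size of this step stays open, and the step to the nitro compound, compound 3, cannot be read at all. Also open, as far as these compounds go, is how the number in this assay would respond to an amine or a carboxylic acid on the phenyl ring at this position.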